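A few compounds are considered here, and "the series" means these few. Any claim that something is new, unique, unknown or untested is made for them only; others in the source may bear on it.

Measured so far:
compound 1, `COc1nc(OC)nc(Sc2ccccc2C(=O)N[C@@H](C)C(=O)OCc2ccccc2)n1`: 1.34%
compound 2, `O=c1nc(SCc2ccccc2)nc(SCc2cccc(F)c2)[nH]1`: 4.18%

Both values come from an assay for inhibition of Pro-cathepsin H (Homo sapiens), read by fluorescence, tested at 50 uM; a higher number here means more inhibition at the concentration tested (going by the name of the read-out), a lower number less inhibition. Within the data shown here, no step between compound 1 and compound 2 is at hand, so only the two numbers speak. In this assay compound 2 gives 4.18% and compound 1 gives 1.34%; the gap between them lies within the scatter, so neither stands apart from the other, and both sit at the low end of the read-out.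

Compound 3, `O=c1nc(SCc2ccccc2)nc(SCC2CCCC2)[nH]1`, is not yet measured in this assay. It differs from compound 2 in one place: cyclopentyl in place of 3-fluorophenyl on a saturated chain carbon bound to a sulfur. The cyclopentyl enters where the 3-fluorophenyl leaves, on a saturated chain carbon bound to a sulfur. Among the measured compounds shown here, no measured pair shows what such a change does here, so no step beyond the scatter is expected in either direction. The step of a number 0.2 percentage points lower from compound 2 to compound 3 (within the scatter) is expected to be flat. Compound 3 is expected to give 4% in this assay, between -5% and 13%.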

Compound 3, a percentage reported as inhibition, at one concentration (the size of the read-out at that concentration, not a potency): 10.6%
For compound 3 the middle estimate is 6.6 percentage points below the measured one, within the range that was stated.
By their numbers in this assay, from the lowest: compounds 1, 2 and 3 (each within the scatter of the next).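

In this assay, the first step read at this position, on a saturated chain carbon bound to a sulfur, is a number 6.4 percentage points higher from compound 2 to compound 3 (within the scatter) and stays within the scatter on swapping 3-fluorophenyl for cyclopentyl. For this pair, the read-out therefore does not separate an aromatic six-membered ring from a non-aromatic five-membered ring of carbon only, and the 3-fluorobenzyl and cyclopentylmethyl forms of the difference count as equivalent here. No measured evidence bears on this result.

One pair cannot show whether any group at this place gives a step beyond the scatter, and a primary amine, a carboxylic acid or a longer alkyl chain would test that. The benzyl group on the other sulfur also remains open, as no step among these compounds touches it.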